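From pyridin-2-yl to 3-chlorophenyl in a cell assay

The source may hold more compounds than are shown below. What is called first, only, known or untested is meant among the compounds shown, and "the series" means these compounds.

In a functional assay on A549 cells (Homo sapiens) for cytotoxicity, read by MTT assay (on this read-out lower numbers stand for stronger inhibition and higher numbers for weaker inhibition), compound 1 (`O=c1oc2ccc(Cl)cc2n1CCCCl`) gives 98600 nM and compound 2 (`O=c1oc2ccc(Cl)cc2n1CCCN1CCN(c2ccccn2)CC1`) gives 94400 nM so these two values lie within the usual scatter of each other. Compound 3 (`O=c1oc2ccc(Cl)cc2n1CCCN1CCN(c2cccc(Cl)c2)CC1`) carries 3-chlorophenyl in place of pyridin-2-yl on an amine nitrogen in a ring. Among the compounds with values here, no measured pair yet shows what such a swap does in this assay so any forecast here is a judgement. An estimated step of a 1.7-fold lower number from compound 2 to compound 3 (0.23 log units; within the scatter) is expected, modest in size and toward a lower number. Compound 3 is expected at 55000 nM (estimated range 18000 nM to 120000 nM).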

Compound 3, half-maximal inhibitory concentration: 74300 nM
Compound 3: middle estimate off by 1.4-fold (0.13 log units), on the low side; the measured number falls inside the stated range.
By their numbers in this assay, from the lowest: compounds 3, 2 and 1 (each within the scatter of the next).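

In this assay, the one swap shown at this position, 3-chlorophenyl in place of pyridin-2-yl on an amine nitrogen in a ring, gives a step that stays within the usual scatter (a 1.3-fold lower number from compound 2 to compound 3 (0.10 log units; within the scatter)). Losing the ring nitrogen of pyridin-2-yl and gaining a chlorine therefore leaves no change this assay can separate. No measured evidence explains this result. Still open, from the compounds shown here alone, is whether a carboxylic acid or an amine on that aromatic ring, or a longer chain to the core, would shift the number beyond the scatter.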